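A few compounds are considered here, and "the series" means these few. Any claim that something is new, unique, unknown or untested is made for them only; others in the source may bear on it.

In an ADME assay on BJ cells (Homo sapiens) for cytotoxicity, with a stated time of 72 h (a higher number here means that more compound is needed for the effect, a lower number that less compound is needed), compound 1 `Cc1cc(NC(=O)Nc2ccc(C)c(Cl)c2)c2ccccc2n1` gives > 25000 nM. That reading is a limit of the assay and not a number, so compound 1 has no exact position on the scale. Compound 2 `Cc1cc(NC(=O)Nc2ccccc2OC(F)(F)F)c2ccccc2n1` gives > 25000 nM, which is also a limit. Compound 3 `Cc1ccc(NC(=O)Nc2cc(C)nc3ccccc23)cc1` gives > 25000 nM, again a limit. The whole measured record therefore comes down to one observation: the limit of > 25000 nM in this assay, at which 3 of the 3 values shown sit.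

Among the measured compounds shown here, the only measured step is a step that the two limits leave unreadable from compound 1 to compound 3, where hydrogen stands in place of chloro on an aromatic carbon. It offers no size to carry forward, and it concerns a different change from the one considered here.

Compound 4 `COc1ccc(NC(=O)Nc2cc(C)nc3ccccc23)cc1Cl` keeps the core of compound 1 and differs from it in one place: methoxy in place of methyl on an aromatic carbon. In words, methoxy stands in place of methyl on an aromatic carbon, ortho to a chloro group and para to a large group. For the measured compounds named here, no measured step tests this swap, so the expectation has to rest on the shared reading. No step beyond the scatter is expected, because of the limit of > 25000 nM in this assay, at which 3 of the 3 values shown sit. The expected change is a number no higher from compound 1 to compound 4 (the limit leaves the size open). A report of only a limit is the likeliest outcome for the next measurement. For compound 4 the estimated value is 25000 nM, with an expected range from 12000 nM to 50000 nM.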

Compound 4, half-maximal effective concentration: 23000 nM
Compound 4: middle estimate off by 1.1-fold (0.04 log units), on the high side; low and high end bracket the measured number.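

Compound 4 brings the first exact number into this record: in this assay compound 4 gives 23000 nM, so the scale now holds a measured point. Compound 1 still stands at > 25000 nM, which is a limit of the assay and not a number. Placing methoxy in place of methyl on this aromatic carbon, ortho to a chloro group and para to a large group, gives an at least 1.0-fold lower number from compound 1 to compound 4 (0.03 log units; that floor lies within the scatter), so this change has a readable floor, but that floor does not separate the two compounds, and the full size of the step stays unknown.

Going by these compounds, a single swap at one position cannot show how this position responds more generally, so it remains open whether an amine, a carboxylic acid or a longer chain such as ethoxy in the same place would give a clearly different number. It also remains open whether methoxy would give a similar reading without the neighbouring chloro group, since the compounds shown test methoxy only alongside chloro.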